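The source may report more compounds than this note shows. Statements on the series, on what has been measured and on what is new or still open speak of the compounds shown alone.

Measured compounds in this assay:

Compound 1, `O=C(/C=C\c1ccc(O)cc1)N1N=C(c2ccncc2)OC1c1c[nH]c2ccccc12`, gives > 30 ug/mL, a limit of the assay and not a number.
Compound 2, `O=C(/C=C\c1ccccc1[N+](=O)[O-])N1N=C(c2ccncc2)OC1c1c[nH]c2ccccc12`, gives > 30 ug/mL, likewise a limit.
Compound 3, `O=C(/C=C\c1ccccc1F)N1N=C(c2ccncc2)OC1c1c[nH]c2ccccc12`, gives > 30 ug/mL, likewise a limit.

All three share one core and differ only in the aryl group on the double-bonded chain carbon. In an ADME assay on A549 cells (Homo sapiens) for cytotoxicity, read by MTT assay, with a stated time of 48 h (a lower number here means a stronger inhibitor of growth, a higher number a weaker inhibitor of growth), compound 2 stands only at a limit, and the two further values shown are limits as well; all three sit at the limit of > 30 ug/mL in this assay, at which 3 of the 3 values shown sit. Hence the steps among them carry no readable size: a step that the two limits leave unreadable from compound 1 to compound 2, a step that the two limits leave unreadable from compound 1 to compound 3 and a step that the two limits leave unreadable from compound 2 to compound 3.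

The next compound, compound 4, `O=C(/C=C\c1ccc(F)cc1)N1N=C(c2ccncc2)OC1c1c[nH]c2ccccc12`, differs from compound 2 by 4-fluorophenyl in place of 2-nitrophenyl on a double-bonded chain carbon bound to a double-bonded chain carbon. For the measured compounds named here, the measured step that comes closest, the fluoro-for-nitro exchange from compound 2 to compound 3, is itself unreadable, and no measured step separates the positions of fluoro on the ring. Going by the values given here, nothing among the measured compounds therefore gives a direction or a size for the step from compound 2 to compound 4 in this assay; the expectation is simply that compound 4 will again sit at or near the limit, with an expected step that the limit leaves unreadable from compound 2 to compound 4. Compound 4 is accordingly estimated at 40 ug/mL, within a range from 15 ug/mL to 120 ug/mL, and most likely reported only as a limit.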

Compound 4, concentration for 50% growth inhibition: > 30 ug/mL
Compound 4: a limit, no number; the forecaster's own chance of this, stated with the estimate: 80%; the middle value does not contradict the limit.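

In this assay compound 4 gives > 30 ug/mL, a limit of the assay and not a number. Its steps to compound 1, compound 2 and compound 3 cannot be read, and all four compounds stand at one limit: the limit of > 30 ug/mL in this assay, at which 4 of the 4 values shown sit.

No compound shown carries a number, which leaves open whether the aryl group on the double-bonded chain carbon changes growth inhibition at all.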